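The source may report more compounds than this note shows. Statements on the series, on what has been measured and on what is new or still open speak of the compounds shown alone.

Of the compounds shown here, three that share one core have been measured in a functional assay on Huh-7 cells (Homo sapiens) for antiproliferative activity, read by sulforhodamine B assay, with a stated time of 72 h; a higher number here means a weaker inhibitor, a lower number a stronger inhibitor. Compound 1 `FC(F)(F)c1ccc(CN2CCN(Cc3cc(-c4ccc(OCc5ccccc5Cl)cc4)on3)CC2)cc1` gives 1000 nM. Going by the values given here, compound 2 `COc1ccc(COc2ccc(-c3cc(CN4CCN(Cc5ccc(C(F)(F)F)cc5)CC4)no3)cc2)cc1` gives 3200 nM, and the single change between them, a 4-methoxyphenyl in place of a 2-chlorophenyl on the saturated chain carbon bound to an oxygen on the aromatic ring, gives a 3.2-fold higher number from compound 1 to compound 2 (0.51 log units; beyond the scatter). Compound 3 `N#Cc1cccc(COc2ccc(-c3cc(CN4CCN(c5ccc(C(F)(F)F)cc5)CC4)no3)cc2)c1` gives 2200 nM, the second highest of the three numbers; its gap to compound 2 lies within the scatter, while its number sits lower than that of compound 1 by more than the scatter.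

Compound 4 `CC(C)(C)OC(=O)N1CCN(Cc2cc(-c3ccc(OCc4cccc(C#N)c4)cc3)on2)CC1` has not yet been measured. It differs from compound 3 in one place: tert-butoxycarbonyl in place of 4-(trifluoromethyl)phenyl on an amine nitrogen in a ring. Among the compounds with values here, no measured step alters the group on this ring nitrogen; the only recorded step concerns a different part of the molecule and so says nothing about the change here. With no anchor, the step from compound 3 to compound 4 is expected to be a 2.7-fold higher number from compound 3 to compound 4 (0.44 log units; beyond the scatter), toward a higher number, with wide uncertainty. Compound 4 is therefore estimated at 6000 nM in this assay, within a range from 2000 nM to 20000 nM.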

Compound 4, half-maximal inhibitory concentration: 6100 nM
Compound 4: middle estimate off by 1.0-fold (0.01 log units), on the low side; low and high end bracket the measured number.
By their numbers in this assay, from the lowest: compound 1; then compounds 3, 2 and 4 (each within the scatter of the next, the first and the last beyond it).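

The group on this ring nitrogen matters in this assay: replacing the 4-(trifluoromethyl)phenyl with tert-butoxycarbonyl gives a 2.8-fold higher number from compound 3 to compound 4 (0.44 log units; beyond the scatter), a modest step that leaves compound 4 with a measurable number. This single swap changes several things at once, removing an aromatic ring and adding a carbonyl and two hydrogen-bond acceptors, so the step cannot be assigned to any one of them. No supporting evidence is available to explain the change.

On these data alone, it remains open whether an unsubstituted phenyl, which keeps the aromatic ring without the trifluoromethyl, or an acetyl group, which keeps the carbonyl without the tert-butyl, would fall nearer compound 3 or compound 4. It is also unknown whether this step would be similar in size with a group other than the nitrile-bearing benzyl at the far end of the molecule.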